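Swapping methoxy for trifluoromethyl on a bis-benzylidene core

The compounds below may be only part of what the source reports. "The series", "measured", "known", "first", "only" and "open" are said of these compounds alone.

Measured compounds in a functional assay on MCF7 cells (Homo sapiens) for cytotoxicity, read by CCK-8 assay, with a stated time of 72 h; on this read-out higher numbers stand for weaker inhibition and lower numbers for stronger inhibition:
- compound 1, `C=CCn1c(=O)/c(=C\c2cccc(F)c2)[nH]c(=O)/c1=C\c1ccccc1OC`: 13700 nM
- compound 2, `C=CCn1c(=O)/c(=C\c2ccccc2OC)[nH]c(=O)/c1=C\c1ccccc1OC`: 41100 nM

Among the measured compounds shown here, compound 2 stands highest of the two numbers measured so far in this assay; its nearest neighbour is compound 1, and the only measured step, a 3.0-fold higher number from compound 1 to compound 2 (0.48 log units; beyond the scatter), separates them. For the measured compounds named here, that step exchanges the aryl group on one double-bonded chain carbon, and it is the only comparison available.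

Compound 3, `C=CCn1c(=O)/c(=C\c2ccccc2C(F)(F)F)[nH]c(=O)/c1=C\c1ccccc1OC`, has not yet been measured. It differs from compound 2 at the same arm: trifluoromethyl in place of methoxy on an aromatic carbon, on an aromatic carbon of a six-membered aromatic ring of carbon only, ortho to a large group. Going by the values given here, no measured pair tests trifluoromethyl against methoxy directly, so the step from compound 1 to compound 2 is the only guide, and it bears on the change only loosely, since it moves both the kind and the position of the substituent.

Given that loose guide, compound 3 is expected to give 22000 nM in this assay, with a range of 7000 nM to 65000 nM, which corresponds to an estimated step of a 1.9-fold lower number from compound 2 to compound 3 (0.27 log units; within the scatter).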

Compound 3, half-maximal inhibitory concentration: 6500 nM
The estimate for compound 3 lay 3.4-fold (0.53 log units) above the measured number; the measured number lies below the stated range.
By their numbers in this assay, from the lowest: compound 3; then compound 1; then compound 2.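

In this assay, the change from 2-methoxyphenyl to 2-(trifluoromethyl)phenyl gives a 6.3-fold lower number from compound 2 to compound 3 (0.80 log units; beyond the scatter). With the substituent held on the same aromatic carbon, ortho to a large group, the kind of group alone moves the number, which the earlier step could not show, since it changed kind and position together. The exchange of 3-fluorophenyl for 2-(trifluoromethyl)phenyl gives a 2.1-fold lower number from compound 1 to compound 3 (0.32 log units; beyond the scatter), so a substituent at this place does not in itself go with a higher number, and the high number of compound 2 belongs to methoxy there rather than to the place. The compounds shown offer no evidence on why this arm responds in this way.

Still open, going by these compounds, is whether the lower number follows from trifluoromethyl in particular, since a nitrile, a chlorine atom or an amine on the same aromatic carbon would test how far the result extends, and trifluoromethyl at the position held by fluorine in compound 1 would separate kind from place for that pair. On these data alone, the 2-methoxyphenyl on the second arm is also shared by all three compounds, so whether the same change holds with a different group there remains unknown.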